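This account rests on a few compounds, and the source may have more. Where it says the series, first, only, none or still open, it means among the compounds named here.

Measured so far in an ADME assay on MDCK cells (Canis lupus familiaris) for permeability, in the apical to basolateral direction; on this read-out lower numbers stand for lower permeability and higher numbers for higher permeability:
compound 1 `CC(C)C(/C=C1\NC(=O)NC1=O)c1ccc(-c2ccc3cccc(F)c3c2)[nH]c1=O` gives 12.3 10^-6 cm/s;
compound 2 `CC(C)C(CC1C(=O)NC(=O)N1C)c1ccc(-c2ccc3cccc(F)c3c2)[nH]c1=O` gives 17.6 10^-6 cm/s.

Going by the values given here, of these two numbers, compound 2 carries the higher one, but its only neighbour is compound 1 and the gap is a 1.4-fold higher number from compound 1 to compound 2 (0.16 log units; within the scatter), so the two compounds cannot be told apart in this assay. The next compound, compound 3 `CC(C)C(/C=C1\SC(=O)NC1=O)c1ccc(-c2ccc3cccc(F)c3c2)[nH]c1=O`, differs from compound 2 by a group of 8 heavy atoms (4 carbon, 1 nitrogen, 2 oxygen, 1 sulfur; one five-membered non-aromatic ring with 2 hetero atoms) in place of a group of 9 heavy atoms (5 carbon, 2 nitrogen, 2 oxygen; one five-membered non-aromatic ring with 2 hetero atoms), on a saturated chain carbon bound to an aromatic carbon and a saturated chain carbon. Among the compounds with values here, only one measured step bears on a change at this place in the molecule: the ring swap at the same saturated chain carbon, a 1.4-fold higher number from compound 1 to compound 2 (0.16 log units; within the scatter), which stayed within the scatter. With a single such comparison, and one that shows little movement, there is no basis for expecting a large shift in either direction; the safest reading is that a further change of the five-membered ring at this position will again move the number little. The expected step is therefore a 1.4-fold lower number from compound 2 to compound 3 (0.13 log units; within the scatter), not beyond the scatter. Compound 3 is thus estimated at 13 10^-6 cm/s, with a plausible range from 5 10^-6 cm/s to 30 10^-6 cm/s.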

Compound 3, apparent permeability: 15.4 10^-6 cm/s
Beside the measured number, compound 3's estimate is 1.2-fold (0.07 log units) below it; low and high end bracket the measured number.
By their numbers in this assay, from the lowest: compounds 1, 3 and 2 (each within the scatter of the next).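

Going from the (3-methyl-2,5-dioxoimidazolidin-4-yl)methyl group to the sulfur-bearing group, which also has one more double bond outside aromatic rings, gives a 1.1-fold lower number from compound 2 to compound 3 (0.06 log units; within the scatter) in this assay, while trading one nitrogen of the group for one sulfur, with the carbon and oxygen counts unchanged, gives a 1.3-fold higher number from compound 1 to compound 3 (0.10 log units; within the scatter) on the same read-out. Both steps stay within the scatter, so a sulfur in this five-membered ring leaves the number where the two nitrogen-containing rings had it, and all three compounds read as one level in this assay. Nothing available explains why these swaps leave the number so still.

On these data alone, all three groups keep a five-membered non-aromatic ring with 2 hetero atoms, so it remains open whether a carboxylic acid, an amine or a plain longer chain on this saturated chain carbon would move the number beyond the scatter. The step from compound 2 also changes several features at once, and a sulfur-bearing ring with the same number of double bonds as the group it replaces would be needed to separate them.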